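A few compounds are considered here, and "the series" means these few. Any claim that something is new, unique, unknown or untested is made for them only; others in the source may bear on it.

Measured in a functional assay on HeLa cells (Homo sapiens) for inhibition, read by sulforhodamine B assay; a higher number here means a weaker inhibitor, a lower number a stronger inhibitor:
- compound 1 `COc1ccccc1NC1=CC(=O)c2nc3n(c2C1=O)[C@H]1OC[C@@H](O)[C@H]1OC3`: 2950 nM
- compound 2 `O=C1C(NC2CC2)=CC(=O)c2c1nc1n2[C@H]2OC[C@@H](O)[C@H]2OC1`: > 16000 nM

The value for compound 2 is a limit of the assay and not a number. Going by the values given here, that leaves compound 1 with the only true number in this assay, so no ranking is possible.

Compound 3 `Cc1ccc(NC2=CC(=O)c3nc4n(c3C2=O)[C@H]2OC[C@@H](O)[C@H]2OC4)cc1` has 4-methylphenyl in place of 2-methoxyphenyl on an amine nitrogen. Among the compounds with values here, no measured step covers this change. The estimate therefore starts from compound 1 at 2950 nM, since one six-membered aromatic ring stays on that nitrogen. The step of a 1.0-fold higher number from compound 1 to compound 3 (0.01 log units; within the scatter) is expected to stay within the scatter, with no direction favoured. For compound 3 the expected value is 3000 nM, with an estimated range of 800 nM to 11000 nM.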

Compound 3, half-maximal inhibitory concentration: 3860 nM
Beside the measured number, compound 3's estimate is 1.3-fold (0.11 log units) below it; measured number inside the range.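

On the amine nitrogen, 4-methylphenyl in place of 2-methoxyphenyl gives a step within the scatter in this assay (a 1.3-fold higher number from compound 1 to compound 3 (0.12 log units; within the scatter)), so this exchange of one six-membered aromatic ring for another does not separate the two compounds. Going by these compounds alone, this is the first readable step, and it shows that the 2-methoxyphenyl group can be replaced without a change beyond the scatter. Nothing shown gives a cause for this step.

The step cannot separate loss of the methoxy group from gain of the methyl group. How a benzyl group or a pyridine ring on that nitrogen would read stays open, and compound 2 offers no comparison, its value being a limit of the assay and not a number: the limit of > 16000 nM in this assay, at which 1 of the 3 values shown sits.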